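Ring-amine substituent series: cyclohexyl replaces isobutyl

The source may hold more compounds than are shown below. What is called first, only, known or untested is meant among the compounds shown, and "the series" means these compounds.

In an assay on HEK293 cells for positive allosteric modulation of metabotropic glutamate receptor 5 (Homo sapiens), read by FLIPR, with a stated time of 1 h (a higher number here means that more compound is needed for the effect, a lower number that less compound is needed), compound 1 `CCN1CCc2nc(C#Cc3ccccc3)sc2C1` gives > 10000 nM, which is a limit of the assay rather than a number. Compound 2 `CC(C)CN1CCc2nc(C#Cc3ccccc3)sc2C1` likewise gives only a limit, > 10000 nM, in this assay. The step that the two limits leave unreadable from compound 1 to compound 2 cannot be sized because of the limit of > 10000 nM in this assay, at which 2 of the 2 values shown sit. Compound 2 thus stands at the limit of this assay, with no measured number to anchor it. Compound 3 `C(#Cc1nc2c(s1)CN(C1CCCCC1)CC2)c1ccccc1` differs from compound 2 by cyclohexyl in place of isobutyl on an amine nitrogen in a ring. For the measured compounds named here, the only measured step at this amine nitrogen is the one from compound 1 to compound 2, and it is unreadable; no measured step therefore bears on the size or direction of the present change, and nothing beyond the scatter of this assay can be expected from it. Compound 3 is accordingly expected to remain near the limit of this assay, estimated at 15000 nM, within 5000 nM to 50000 nM, meaning an expected step that the limit leaves unreadable from compound 2 to compound 3.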

Compound 3, half-maximal effective concentration: > 10000 nM
Compound 3 was reported as a limit; the forecaster's own chance of this, stated with the estimate: 75%; the middle value lies beyond the limit too.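

For the compounds shown here, no step among compound 1, compound 2 and compound 3 can be read in this assay, because all three are reported only as a limit: the limit of > 10000 nM in this assay, at which 3 of the 3 values shown sit. As far as these compounds go, whether ethyl, isobutyl and cyclohexyl on the amine nitrogen in a ring differ at all in this assay stays open.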